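Amide-ring substituent swap: pyridinyl to methoxyphenyl

A few compounds are considered here, and "the series" means these few. Any claim that something is new, unique, unknown or untested is made for them only; others in the source may bear on it.

Measured so far:
compound 1 `Cn1cc(C2=C(c3nn(CCCN4CCCCC4)c4ncccc34)C(=O)N(c3ccccn3)C2=O)c2ccccc21` — > 100000 nM
compound 2 `Cn1cc(C2=C(c3nn(CCCn4ccnc4)c4ncccc34)C(=O)N(c3ccccc3)C2=O)c2ccccc21` — 6800 nM

Two compounds sharing the core have been run through a functional assay on KB cells (Homo sapiens) for antiproliferative activity, read by MTT assay, with a stated time of 48 h; on this read-out lower numbers stand for stronger inhibition and higher numbers for weaker inhibition. Compound 1 gives > 100000 nM, which is a limit of the assay rather than a number. This places compound 1 at the limit of > 100000 nM in this assay, at which 1 of the 2 values shown sits. Among the measured compounds shown here, compound 2, with a different ring on the amide-type nitrogen and a different chain on the pyrazole-type nitrogen, gives 6800 nM in this assay; no single-point step connects it to compound 1, so the two values are simply set side by side.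

The unmeasured compound 3 `COc1ccc(N2C(=O)C(c3cn(C)c4ccccc34)=C(c3nn(CCCN4CCCCC4)c4ncccc34)C2=O)cc1` differs from compound 1 in one place: 4-methoxyphenyl in place of pyridin-2-yl on an amide-type nitrogen in a ring.

Since compound 1 only offers a limit, the size of the step cannot be drawn from any measured pair. With compound 2 showing a number at 6800 nM while carrying a carbon-only aromatic ring on the same nitrogen, a move toward measurable inhibition is expected, yet one of modest size and with wide uncertainty. Compound 3 is estimated at 20000 nM, expected to lie between 4000 nM and 100000 nM, which would mean a step of an at least 5.0-fold lower number from compound 1 to compound 3 (0.69 log units; beyond the scatter).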

Compound 3, half-maximal inhibitory concentration: 44000 nM
Beside the measured number, compound 3's estimate is 2.2-fold (0.34 log units) below it, within the range that was stated.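

In this assay, placing 4-methoxyphenyl in place of pyridin-2-yl on the amide-type nitrogen, with the rest of the structure unchanged, gives an at least 2.2-fold lower number from compound 1 to compound 3 (0.35 log units; beyond the scatter). This is the first comparison shown that isolates this position, and it shows that the group on this nitrogen alone can change the read-out, since the chain on the other side of the molecule stays the same in both compounds. The true size of the step cannot be stated, and only its lower bound is known, because compound 1 stands at a limit of the assay rather than at a number: the limit of > 100000 nM in this assay, at which 1 of the 3 values shown sits.

The compounds shown leave open whether the change depends on the methoxy group or on the loss of the ring nitrogen, a question that a plain phenyl group or a pyridin-3-yl group on this nitrogen, carrying the same chain, would help to settle. They also leave open whether a 4-hydroxyphenyl or 4-chlorophenyl group would move the value further in either direction, and whether the same swap would produce a similar step with a different chain on the other side of the molecule.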